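Bromo in Place of Methyl: Expecting Compound 4

The source may hold more compounds than are shown below. What is called first, only, known or untested is meant among the compounds shown, and "the series" means these compounds.

Of the compounds shown here, three sharing one core have been tested in a functional assay on MCF7 cells (Homo sapiens) for inhibition, read by sulforhodamine B assay, with a stated time of 48 h; on this read-out lower numbers stand for stronger inhibition of growth and higher numbers for weaker inhibition of growth. Compound 1 `S=C(N/N=C/c1cccs1)Nc1cccc2ccccc12` reaches only the limit of the assay, > 100000 nM. Compound 2 `CCc1ccc(NC(=S)N/N=C/c2cccs2)cc1` likewise gives only a limit, > 100000 nM. Within the data shown here, compound 3 `Cc1ccc(NC(=S)N/N=C/c2cccs2)cc1` is the only one with a true number, giving 38600 nM in this assay. Two of the three results sit at the limit of > 100000 nM in this assay, at which 2 of the 3 values shown sit. Among the measured compounds shown here, the single measured step, an at least 2.5-fold lower number from compound 2 to compound 3 (0.41 log units; beyond the scatter), runs from a limit to a number and is the only guide to how a change on the six-membered aromatic ring shifts growth inhibition here.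

Compound 4 `S=C(N/N=C/c1cccs1)Nc1ccc(Br)cc1` has not yet been measured. It differs from compound 3 by bromo in place of methyl on an aromatic carbon. For the measured compounds named here, no measured step swaps methyl for bromo, so the step from compound 2 to compound 3 bears on it only loosely, showing that a small change at this place can move the number beyond the scatter. The expected step is a 1.3-fold lower number from compound 3 to compound 4 (0.11 log units; within the scatter), meaning little change in this assay. Compound 4 is therefore estimated at 30000 nM, in the range from 10000 nM to 100000 nM.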

Compound 4, concentration for 50% growth inhibition: < 740 nM
Compound 4 gave a limit, no number; the forecaster's own chance of this, stated with the estimate: 25%; middle value at least 40-fold (1.60 log units) from the limit.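

Among these compounds, on the six-membered aromatic ring, para to a large group, exchanging one small substituent for another can change growth inhibition far more than the earlier compounds suggested: this assay shows an at least 52-fold lower number from compound 3 to compound 4 (1.71 log units; beyond the scatter), even though methyl and bromo each count as 1 heavy atom with no hydrogen-bond donors or acceptors. Bromo in place of ethyl at the same place gives an at least 130-fold lower number from compound 2 to compound 4 (2.13 log units; beyond the scatter), well past the earlier modest shift of an at least 2.5-fold lower number from compound 2 to compound 3 (0.41 log units; beyond the scatter). These sizes are only bounds, because compound 4 gives a limit rather than a number: the limit of < 740 nM in this assay, at which 1 of the 4 values shown sits.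

The compounds shown cannot tell whether this gain belongs to bromo alone or would also appear with chloro or fluoro at this place. They also leave open how an amine or a methoxy group there would behave, and why bromo acts as it does.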